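A few compounds are considered here, and "the series" means these few. Any claim that something is new, unique, unknown or untested is made for them only; others in the source may bear on it.

Within the data shown here, in an ADME assay on MDCK cells (Canis lupus familiaris) for cytotoxicity, read by MTT assay (a lower number here means that less compound is tolerated, a higher number that more compound is tolerated), compound 1 (`O=c1cc(-c2ccccc2Cl)oc2ccccc12`) gives 388000 nM and stands higher of the two compounds measured so far. By comparison, compound 2 (`O=c1cc(-c2ccc(Cl)cc2)oc2ccccc12`) gives 115000 nM and lies lower, a gap beyond the usual scatter of repeated measurements. Still unmeasured, compound 3 (`COc1ccccc1-c1cc(=O)c2ccccc2o1`) differs from compound 1 by a single swap, methoxy in place of chloro on an aromatic carbon. Among the measured compounds shown here, no measured pair yet shows what this swap does, so no step beyond the scatter is expected (a 1.7-fold lower number from compound 1 to compound 3 (0.23 log units; within the scatter)). For compound 3 the estimated value is 230000 nM (expected range 70000 nM to 700000 nM).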

Compound 3, half-maximal cytotoxic concentration: 171000 nM
Compound 3: the middle estimate sits 1.3-fold (0.13 log units) above what was measured; the range from low to high includes it.
By their numbers in this assay, from the lowest: compounds 2 and 3 (each within the scatter of the next); then compound 1.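

Among these compounds, at this place on the aromatic ring, ortho to a large group, this assay now gives a first reading of a swap: methoxy in place of chloro brings a 2.3-fold lower number from compound 1 to compound 3 (0.36 log units; beyond the scatter) and so shifts the tolerated concentration, though only modestly. Nothing available gives a cause for this step.

Going by these compounds, it remains open how an amine or a carboxylic acid at this place would compare with chloro and methoxy. On these data alone, it is also open whether the same swap would give a similar step where compound 2 carries its chloro.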